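Aryl ether in place of benzyl ether on the pyridine

A few compounds are considered here, and "the series" means these few. Any claim that something is new, unique, unknown or untested is made for them only; others in the source may bear on it.

Of the compounds shown here, two have been measured so far. Compound 1 `C1=C(c2cncc(OCc3ccccc3)c2)CC2CNCC1C2` is tested in an in vitro assay on SH-SY5Y cells for displacement of a labelled ligand from Neuronal acetylcholine receptor; alpha3/beta4 (Homo sapiens) (a higher number here means a weaker inhibitor, a lower number a stronger inhibitor), where compound 1 gives 44 nM. Compound 2 `C1=C(c2cncnc2)CC2CNCC1C2` gives 58 nM in this assay, and the two numbers lie within the usual scatter of each other, so neither can be placed ahead of the other. Compound 3 `COc1ccccc1Oc1cncc(C2=CC3CNCC(C2)C3)c1` has not yet been measured. It differs from compound 1 in one place: 2-methoxyphenyl in place of benzyl on an oxygen on an aromatic ring. Among the measured compounds shown here, no pair of measured compounds shows the effect of such a change, so there is no step on record to lean on. A move from a benzyl ether to an aryl ether of this kind is expected to leave the value of compound 1 roughly where it is, with a step from compound 1 to compound 3 of a 1.4-fold higher number from compound 1 to compound 3 (0.13 log units; within the scatter) as the estimate. For compound 3 the expected value in this assay is therefore 60 nM, with a range from 15 nM to 250 nM.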

Compound 3, inhibition constant: 56 nM
Compound 3: the middle estimate sits 1.1-fold (0.03 log units) above what was measured; the measured number falls inside the stated range.
By their numbers in this assay, from the lowest: compounds 1, 3 and 2 (each within the scatter of the next).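

Set on the oxygen on the aromatic ring, 2-methoxyphenyl in place of benzyl gives a 1.3-fold higher number from compound 1 to compound 3 (0.10 log units; within the scatter) in this assay. Among the compounds shown here, this is the first step on record at this place, and it shows that the benzyl group of compound 1 can give way to a 2-methoxyphenyl group, with its one hydrogen-bond acceptor, without a difference that can be read in this measurement. The data at hand offer no explanation for this result.

For the compounds shown here, the single step joins two alterations, the loss of the benzyl carbon link to the oxygen and the arrival of the methoxy group, so their separate contributions remain open. Going by these compounds, how a plain phenyl, or a phenyl carrying an amine or a carboxylic acid, would behave on the same oxygen in this assay also remains open.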